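The source may report more compounds than this note shows. Statements on the series, on what has been measured and on what is new or still open speak of the compounds shown alone.

Working notes on the series. In a functional assay on Daudi cells (Homo sapiens) for antiproliferative activity (a higher number here means a weaker inhibitor, a lower number a stronger inhibitor), compound 1 `Nc1ncnc2c1c(-c1ccc(NC(=O)c3ccccc3)cc1)cn2[C@H]1CCN(C[C@@H]2CO2)C1` gives 3180 nM, compound 2 `Nc1ncnc2c1c(-c1ccc(Oc3ccccc3)cc1)cn2C[C@H]1CCCN1C[C@@H](O)CO` gives 14400 nM and compound 3 `Nc1ncnc2c1c(-c1cc3ccccc3o1)cn2[C@H]1CCN(C[C@@H]2CO2)C1` gives 4510 nM. Compound 3 is the second highest number of the three. It lies within the scatter of compound 1, while compound 2 has a higher number, beyond the scatter of compound 3.

Next in line is compound 4 `Nc1ncnc2c1c(-c1cc3ccccc3o1)cn2[C@H]1CCN(C[C@H]2CO2)C1`, and the comparison is with compound 3: the two compounds have the same atoms and bonds and differ only in configuration as drawn: 1 of 2 stereo elements differ; a stereocentre at a saturated ring carbon is drawn R in compound 3 and S in compound 4. The atoms and bonds are the same, and a stereocentre at a saturated ring carbon is drawn R in compound 3 and S in compound 4.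

Among the compounds with values here, no pair of measured compounds differs in one place, so the data give no direct measure of such a change. No step beyond the scatter is expected in this assay, in either direction, and the expectation stays anchored on compound 3 at 4510 nM. The estimate amounts to a step of a 1.1-fold lower number from compound 3 to compound 4 (0.03 log units; within the scatter), which is expected to stay within the scatter. For compound 4 the estimated value is 4200 nM, with an expected range of 1800 nM to 9500 nM.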

Compound 4, half-maximal inhibitory concentration: 4210 nM
Beside the measured number, compound 4's estimate is 1.0-fold (0.00 log units) below it; measured number inside the range.
By their numbers in this assay, from the lowest: compounds 1, 4 and 3 (each within the scatter of the next); then compound 2.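

In this assay, within the data shown here, inverting the stereocentre at a saturated ring carbon from R to S gives a 1.1-fold lower number from compound 3 to compound 4 (0.03 log units; within the scatter), the first step that can be read directly. This step isolates configuration alone: the fact that compounds 3 and 4 differ only in the configuration as drawn. Among these compounds, at this stereocentre and with the rest of the structure held constant, this assay therefore does not separate the two drawn forms, something the earlier compounds, none of which formed a single-place pair, could not show.

Among the compounds shown here, this single pair leaves open whether the same inversion would stay within the scatter with the other groups on the shared core, such as the one carried by compound 1. It also leaves open how this assay would respond if a carboxylic acid or a longer chain stood in place of the group bearing this stereocentre.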